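Piperazine swap and tolerated concentration on two cores

This account rests on a few compounds, and the source may have more. Where it says the series, first, only, none or still open, it means among the compounds named here.

Compound 1 `Cc1cc(/C=C/C#N)cc(C)c1Oc1nc(Nc2ccc(N3CCNCC3)cc2)nc2ccsc12`, compound 2 `Cc1cc(/C=C/C#N)cc(C)c1Oc1nc(Nc2ccc(CN3CCN(S(N)(=O)=O)CC3)cc2)nc2ccsc12` and compound 3 `Cc1cc(/C=C/C#N)cc(C)c1Oc1nc(Nc2ccc(CN3CCN(S(N)(=O)=O)CC3)cc2)nc2sccc12` were tested in an ADME assay on MT4 cells (Homo sapiens) for cytotoxicity, read by MTT assay, with a stated time of 5 days; a lower number here means that less compound is tolerated, a higher number that more compound is tolerated. Compound 2 gives 145000 nM, while compound 1 gives 5730 nM. For compound 3 the result is a limit of the assay rather than a number, > 217000 nM. Compound 1 differs from compound 2 by piperazin-1-yl in place of (4-sulfamoylpiperazin-1-yl)methyl on an aromatic carbon, and that change made a 25-fold lower number from compound 2 to compound 1 (1.40 log units; beyond the scatter). Compound 4 `Cc1cc(/C=C/C#N)cc(C)c1Oc1nc(Nc2ccc(N3CCNCC3)cc2)nc2sccc12`, not yet measured, differs from compound 3 by piperazin-1-yl in place of (4-sulfamoylpiperazin-1-yl)methyl on an aromatic carbon, the same change at the same place. Compounds 2 and 3 are built from the same atoms joined differently; the difference between their two cores is not broken down here. Because compound 3 sits at the limit (the limit of > 217000 nM in this assay, at which 1 of the 3 values shown sits), the only measured gauge of the change is the step from compound 2 to compound 1. On that basis compound 4 is expected to show an at least 21-fold lower number from compound 3 to compound 4 (1.33 log units; beyond the scatter) in this assay, a step of about the size seen for compound 1 a 25-fold lower number from compound 2 to compound 1 (1.40 log units; beyond the scatter). Compound 4 is therefore estimated at 10000 nM, with a plausible range from 3000 nM to 60000 nM.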

Compound 4, half-maximal cytotoxic concentration: 4740 nM
Compound 4: the middle estimate sits 2.1-fold (0.32 log units) above what was measured; measured number inside the range.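

In this assay, piperazin-1-yl in place of (4-sulfamoylpiperazin-1-yl)methyl gives an at least 45-fold lower number from compound 3 to compound 4 (1.66 log units; beyond the scatter), so the change lowers the number in the same direction on both cores shown. This new step starts from compound 3, whose result is a limit of the assay and not a number: the limit of > 217000 nM in this assay, at which 1 of the 4 values shown sits.

The direction therefore carries over between these two cores, but equal size is not shown, and two cores say nothing about a third: the same change on two cores in this assay, a 25-fold lower number (1.40 log units; beyond the scatter) from compound 2 to compound 1 and an at least 45-fold lower number (1.66 log units; beyond the scatter) from compound 3 to compound 4; the limit leaves it open whether they differ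

The change removes the sulfamoyl group and the methyl link together, so the compounds shown leave open how much of the step belongs to each. A piperazin-1-ylmethyl group or a 4-sulfamoylpiperazin-1-yl group on the same aromatic carbon would separate the two, and a 4-acetylpiperazin-1-yl group would show whether another group on that piperazine nitrogen behaves like the sulfamoyl group.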